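The compounds below may be only part of what the source reports. "The series", "measured", "known", "first", "only" and "open" are said of these compounds alone.

Measured so far:
- compound 1 `COc1ccc(S(=O)(=O)N2CCc3cccc(NC(=O)C(C)(C)C)c32)cc1`: 359 nM
- compound 2 `COc1ccc(S(=O)(=O)N2CCc3cccc(NCc4ccccc4)c32)cc1`: > 10000 nM (a limit of the assay, not a number)
- compound 3 `COc1ccc(S(=O)(=O)N2CCc3cccc(NS(=O)(=O)c4ccccc4)c32)cc1`: 650 nM

In a functional assay on KB cells (Homo sapiens) for cytotoxicity (a lower number here means a stronger inhibitor, a higher number a weaker inhibitor), compound 3 gives 650 nM. It stands level with compound 1, as the step is a 1.8-fold higher number from compound 1 to compound 3 (0.26 log units; within the scatter). Compound 2 reports only a limit, > 10000 nM.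

Compound 4 `COc1ccc(S(=O)(=O)N2CCc3cccc(NC(=O)c4ccc(C#N)cc4)c32)cc1` is compound 3 with one change: (4-cyanophenyl)carbonyl in place of phenylsulfonyl on a nitrogen on an aromatic ring. The closest measured precedent is a 1.8-fold higher number from compound 1 to compound 3 (0.26 log units; within the scatter), where a carbonyl group and a sulfonyl group on that nitrogen could not be told apart. The large steps of an at least 27-fold higher number from compound 1 to compound 2 (1.44 log units; beyond the scatter) and an at least 15-fold lower number from compound 2 to compound 3 (1.18 log units; beyond the scatter) both involve benzyl, which compound 4 does not carry, so they set no size here. Going by the values given here, no measured compound has the 4-cyanophenyl group, which keeps the range wide. With compound 1 at 359 nM as the carbonyl reference, no change beyond the scatter is expected. The expected step is a 1.9-fold lower number from compound 3 to compound 4 (0.27 log units; within the scatter). Compound 4 is estimated at 350 nM, with an expected range from 60 nM to 1500 nM.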

Compound 4, half-maximal inhibitory concentration: 105 nM
For compound 4 the middle estimate is 3.3-fold (0.52 log units) above the measured one; measured number inside the range.
By their numbers in this assay, from the lowest: compound 4; then compounds 1 and 3 (each within the scatter of the next). At a limit, above all of these: compound 2.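

Earlier, a carbonyl and a sulfonyl on this nitrogen could not be told apart, but in this assay this change gives a gap beyond the scatter: a 6.2-fold lower number from compound 3 to compound 4 (0.79 log units; beyond the scatter). What the carbonyl carries also matters, since 4-cyanophenyl and tert-butyl on the carbonyl carbon differ, with a 3.4-fold lower number from compound 1 to compound 4 (0.53 log units; beyond the scatter). The step of an at least 95-fold lower number from compound 2 to compound 4 (1.97 log units; beyond the scatter) is only a bound, as compound 2 sits at a limit: the limit of > 10000 nM in this assay, at which 1 of the 4 values shown sits.

Compound 4 differs from compound 3 both in the carbonyl and in the nitrile, so the shift cannot be assigned to either one, and a plain phenylcarbonyl group would separate the two. As far as these compounds go, it also remains open whether an amine or a carboxylic acid in place of the nitrile would keep the lower number.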